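The compounds below may be only part of what the source reports. "The series", "measured", "known", "first", "only" and "open" are said of these compounds alone.

Working notes on the series. Compound 1 `CC1CCN(C2CCN(S(=O)(=O)c3cccc(-c4ccccc4F)c3)CC2)CC1` gives in an ADME assay on HCT-116 cells (Homo sapiens) for cytotoxicity, read by CellTiter-Glo, with a stated time of 72 h (on this read-out lower numbers stand for stronger inhibition and higher numbers for weaker inhibition), only a limit of the assay, > 5000 nM. Compound 2 `Cc1c(C)c(S(=O)(=O)N2CCC(N3CCC(C)CC3)CC2)c(C)c2c1OC(C)(C)C2` returns only a limit in this assay, > 10000 nM. Compound 3 `CC1CCN(C2CCN(S(=O)(=O)c3ccc(OCc4ccccc4)cc3)CC2)CC1` returns only a limit in this assay, > 5000 nM. The three values are the limit of > 5000 nM in this assay, at which 2 of the 3 values shown sit, and (the limit of > 10000 nM in this assay, at which 1 of the 3 values shown sits), so compound 1 stands without a number that would set it apart from either of the others. Compound 4 `CC1CCN(C2CCN(S(=O)(=O)c3cccc(-c4ccccc4)c3)CC2)CC1` is not yet measured in this assay. It differs from compound 1 by hydrogen in place of fluoro on an aromatic carbon. Among the compounds with values here, no step between measured compounds is available on which to size this change. With every value a limit, no step beyond the scatter is expected, estimated as a step that the limit leaves unreadable from compound 1 to compound 4. Compound 4 is expected to give about 8000 nM in this assay, within 3000 nM to 25000 nM, most likely reported again as a limit.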

Compound 4, half-maximal inhibitory concentration: > 5000 nM
Compound 4 was reported as a limit; the forecaster's own chance of this, stated with the estimate: 85%; the middle value is on the limit's open side.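

Compound 1 and compound 4 both stand only as limits in this assay, and the step between them cannot be read. The compounds shown leave open whether 2-fluorophenyl and phenyl differ at all in this assay.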